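A few compounds are considered here, and "the series" means these few. Any claim that something is new, unique, unknown or untested is made for them only; others in the source may bear on it.

Three compounds of this series have numbers in an assay for inhibition of Fatty-acid amide hydrolase 1 (Rattus norvegicus); on this read-out higher numbers stand for weaker inhibition and lower numbers for stronger inhibition. Compound 1 `O=C(CCCCC#Cc1ccccn1)c1ncc(-c2ccccn2)o1` gives 280 nM. Compound 2 `CC(C)(C)OC(=O)Nc1ccc(C#CCCCCC(=O)c2ncc(-c3ccccn3)o2)cc1` gives 23 nM. Compound 3 `O=C(CCCCC#Cc1cccc(F)c1)c1ncc(-c2ccccn2)o1` gives 3.2 nM, the lowest of the three, with compound 2 nearest and compound 1 furthest from it. Among the measured compounds shown here, the one step that exchanges a single group, an 88-fold lower number from compound 1 to compound 3 (1.94 log units; beyond the scatter), shows that the aryl group on the triple-bonded carbon shifts the number strongly.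

Compound 4 `O=C(CCCCC#Cc1ccc([N+](=O)[O-])cc1)c1ncc(-c2ccccn2)o1` is the next analogue. Relative to compound 3 it carries 4-nitrophenyl in place of 3-fluorophenyl on a triple-bonded carbon. For the measured compounds named here, no measured step exchanges one substituted phenyl for another, so the bearing of the earlier data is indirect: compound 3 with 3-fluorophenyl and compound 2 with a substituted phenyl both give low numbers, while compound 1 with pyridin-2-yl gives the high one. On these data alone, a substituted phenyl is kept in compound 4, so a number in the low range of compound 2 and compound 3 is expected rather than a return toward compound 1; the exact position is unknown and the step of a 3.1-fold higher number from compound 3 to compound 4 (0.49 log units; beyond the scatter) is expected to be modest. Compound 4 is therefore estimated at 10 nM, with a range from 2 nM to 50 nM.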

Compound 4, inhibition constant: 31 nM
Compound 4: middle estimate off by 3.1-fold (0.49 log units), on the low side; the measured number falls inside the stated range.
By their numbers in this assay, from the lowest: compound 3; then compounds 2 and 4 (each within the scatter of the next); then compound 1.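

The step (a 9.7-fold higher number from compound 3 to compound 4 (0.99 log units; beyond the scatter)) in this assay shows that this position on the triple-bonded carbon distinguishes one substituted phenyl from another, whereas the earlier single-group step compared only a substituted phenyl with pyridin-2-yl. Among the compounds shown here, the step (a 9.0-fold lower number from compound 1 to compound 4 (0.96 log units; beyond the scatter)) shows that 4-nitrophenyl also gives a lower number than pyridin-2-yl, so the earlier gain is not confined to 3-fluorophenyl, although this step is smaller than the one to compound 3 (an 88-fold lower number from compound 1 to compound 3 (1.94 log units; beyond the scatter)); the step (a 1.3-fold higher number from compound 2 to compound 4 (0.13 log units; within the scatter)) lies within the scatter, so nitro and (tert-butoxycarbonyl)amino on an aromatic carbon cannot be told apart in this assay. No evidence is available that explains these differences.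

Compound 3 and compound 4 differ in both the substituent and its numbered ring location, so the shown compounds cannot assign the step to either one; 4-fluorophenyl and 3-nitrophenyl would separate the two. Also open, on these data alone, is how a free amine or a carboxylic acid on the phenyl ring, or a shorter chain leading to the triple bond, would read in this assay.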